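Quinoxaline-fused spirooxindole triazoles: aryl swap on the triazole

A few compounds are considered here, and "the series" means these few. Any claim that something is new, unique, unknown or untested is made for them only; others in the source may bear on it.

Measured compounds in this series:
compound 1 `N#CC1=C(N)Oc2c(N)cc3nc4ccccc4nc3c2C12C(=O)N(Cc1cnnn1-c1ccccc1Br)c1ccccc12`: 30700 nM
compound 2 `CC(=O)Nc1ccc(-n2nncc2CN2C(=O)C3(C(C#N)=C(N)Oc4c(N)cc5nc6ccccc6nc5c43)c3ccccc32)cc1`: > 50000 nM
compound 3 `CCOc1ccc(-n2nncc2CN2C(=O)C3(C(C#N)=C(N)Oc4c(N)cc5nc6ccccc6nc5c43)c3ccccc32)cc1`: 26800 nM

All three share one core and differ only in the aryl group on the triazole nitrogen. In a functional assay on MCF7 cells (Homo sapiens) for antiproliferative activity, read by MTT assay, with a stated time of 48 h (a higher number here means a weaker inhibitor, a lower number a stronger inhibitor), compound 1 gives 30700 nM and compound 3 gives 26800 nM; the two sit within the scatter of each other, a 1.1-fold lower number from compound 1 to compound 3 (0.06 log units; within the scatter). For compound 2 the result is a limit, > 50000 nM (the limit of > 50000 nM in this assay, at which 1 of the 3 values shown sits), so the step of an at least 1.6-fold higher number from compound 1 to compound 2 (0.21 log units; that floor lies within the scatter) has only a floor, and that floor lies within the scatter. Compound 3 thus stands together with compound 1 among the two numbers, with the third value being a limit.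

The next compound, compound 4 `Cc1cc(C)cc(-n2nncc2CN2C(=O)C3(C(C#N)=C(N)Oc4c(N)cc5nc6ccccc6nc5c43)c3ccccc32)c1`, changes the same position: 3,5-dimethylphenyl in place of 4-ethoxyphenyl on an aromatic nitrogen. The measured steps that bear on it are the two aryl swaps from compound 1, neither of which moved this assay beyond the scatter. On that basis no step beyond the scatter is expected from compound 3 to compound 4, a 1.1-fold higher number from compound 3 to compound 4 (0.05 log units; within the scatter). Compound 4 is therefore estimated at 30000 nM, with a range from 12000 nM to 75000 nM.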

Compound 4, half-maximal inhibitory concentration: > 50000 nM
Compound 4: only a limit was reported; the forecaster's own chance of this, stated with the estimate: 25%; middle value at least 1.6-fold (0.22 log units) from the limit.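

Compound 4 joins compound 2 at the ceiling of this assay, and its result is a limit, not a number: the limit of > 50000 nM in this assay, at which 2 of the 4 values shown sit.

Both readable steps, an at least 1.8-fold higher number from compound 3 to compound 4 (0.27 log units; that floor lies within the scatter) and an at least 1.6-fold higher number from compound 1 to compound 4 (0.21 log units; that floor lies within the scatter), have floors within the scatter, so replacing 4-ethoxyphenyl or 2-bromophenyl with 3,5-dimethylphenyl gives no established change at this position, although it does take the series to the limit for a second time. What compound 4 adds is that reaching the limit does not follow the presence or absence of oxygen on the aryl group: 3,5-dimethylphenyl carries none and compound 4 sits at the limit, yet 2-bromophenyl also carries none and compound 1 gives a number, while compound 2 has the oxygen of its acetamido group and compound 3 the oxygen of its ethoxy group, and those two part ways as well.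

The step between compound 2 and compound 4 cannot be read, as both values are limits. Still open, on these data alone, is how an aryl group bearing an amine or a carboxylic acid, or a longer alkoxy chain in place of ethoxy, would read in this assay.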